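The source may hold more compounds than are shown below. What is called first, only, known or untested is meant among the compounds shown, and "the series" means these compounds.

Series notes. For the measured compounds named here, compound 2 `O=C(/C=C/c1cn(-c2ccccc2)nc1-c1ccncc1)c1ccsc1` gives 1500 nM in a functional assay on MCF7 cells (Homo sapiens) for inhibition, read by sulforhodamine B assay, with a stated time of 72 h (on this read-out higher numbers stand for weaker inhibition and lower numbers for stronger inhibition), the lower of the two numbers measured so far. Compound 1 `O=C(/C=C/c1cn(-c2ccccc2)nc1-c1cccnc1)c1cc[nH]c1` gives 6900 nM in this assay, a gap beyond the scatter; compound 1 differs from compound 2 in more than one place, so no single step can be read from the pair. Compound 3 `O=C(/C=C/c1cn(-c2ccccc2)nc1-c1ccncc1)c1cc[nH]c1` follows from compound 2 by 1H-pyrrol-3-yl in place of thiophen-3-yl on a carbonyl carbon. In this assay the step from compound 2 to compound 3 is expected to be a 2.3-fold higher number from compound 2 to compound 3 (0.37 log units; beyond the scatter), toward weaker inhibition, but with wide uncertainty. Compound 3 is expected near 3500 nM, between 1200 nM and 10000 nM.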

Compound 3, half-maximal inhibitory concentration: 13600 nM
Compound 3: middle estimate off by 3.9-fold (0.59 log units), on the low side; measured number outside the range, above it.
By their numbers in this assay, from the lowest: compound 2; then compounds 1 and 3 (each within the scatter of the next).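

For the compounds shown here, at the carbonyl carbon, 1H-pyrrol-3-yl in place of thiophen-3-yl gives a 9.1-fold higher number from compound 2 to compound 3 (0.96 log units; beyond the scatter) in this assay, the first single-place reading at this position, and it runs toward weaker inhibition. On the aromatic carbon, pyridin-4-yl in place of pyridin-3-yl gives a 2.0-fold higher number from compound 1 to compound 3 (0.29 log units; within the scatter), so this read-out does not separate the two pyridines when 1H-pyrrol-3-yl sits on the carbonyl. Nothing measured here accounts for either step. On these data alone, whether thiophen-3-yl has the same standing alongside pyridin-3-yl remains open. As far as these compounds go, how furan-3-yl or phenyl on the carbonyl carbon would compare also remains open.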